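The compounds below may be only part of what the source reports. "The series", "measured", "known", "first", "only" and "open" are said of these compounds alone.

Among the measured compounds shown here, compound 2 `FC(F)(F)c1cc(COC[C@@H](NCc2nn[nH]n2)c2ccccc2)cc(C(F)(F)F)c1` gives 23 nM in an assay on CHO cells for displacement of a labelled ligand from Substance-P receptor (Homo sapiens) (a lower number here means a stronger inhibitor, a higher number a weaker inhibitor), the higher of the two numbers so far; compound 1 `FC(F)(F)c1cc(COC[C@@H](NCc2nc[nH]n2)c2ccccc2)cc(C(F)(F)F)c1` gives 5 nM, and the two are separated by a 4.6-fold higher number from compound 1 to compound 2 (0.66 log units; beyond the scatter). Compound 3 `CCN(Cc1n[nH]c(O)n1)[C@H](COCc1cc(C(F)(F)F)cc(C(F)(F)F)c1)c1ccccc1` differs from compound 2 by ethyl((5-hydroxy-1H-1,2,4-triazol-3-yl)methyl)amino in place of ((2H-tetrazol-5-yl)methyl)amino on a saturated chain carbon bound to an aromatic carbon and a saturated chain carbon. For the measured compounds named here, that change brings back a 1,2,4-triazole, now carrying a hydroxy group, and adds an ethyl on the amine nitrogen, so only one measured step, a 4.6-fold higher number from compound 1 to compound 2 (0.66 log units; beyond the scatter), speaks to it, and only in part, since the ethyl has no counterpart among the measured compounds. Compound 3 is therefore expected to give 12 nM, within 3 nM to 50 nM, meaning an estimated step of a 1.9-fold lower number from compound 2 to compound 3 (0.28 log units; within the scatter) in this assay.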

Compound 3, half-maximal inhibitory concentration: 0.8 nM
For compound 3 the middle estimate is 15-fold (1.18 log units) above the measured one; measured number below the stated range.
By their numbers in this assay, from the lowest: compound 3; then compound 1; then compound 2.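

In this assay, ethyl((5-hydroxy-1H-1,2,4-triazol-3-yl)methyl)amino gives a 29-fold lower number from compound 2 to compound 3 (1.46 log units; beyond the scatter) and a 6.3-fold lower number from compound 1 to compound 3 (0.80 log units; beyond the scatter). This place therefore accepts a group with more heavy atoms and reaches a lower number than either earlier group did. Nothing given here explains the gain.

Going by these compounds, the hydroxy group and the ethyl arrive together, so their separate shares remain unknown. Also open, on these data alone, is how a propyl in place of the ethyl, or an amino group in place of the hydroxy, would compare.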